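Tri-aziridinyl quinone: notes on the step to compound 4

The source may report more compounds than this note shows. Statements on the series, on what has been measured and on what is new or still open speak of the compounds shown alone.

Compound 3 `CC1=C(N2CC2)C(=O)C(C(C)COC(N)=O)=C(N2CC2)C1=O` stands highest of the three measured: in a functional assay on L1210 cells (Mus musculus), with a stated time of 12 days (on this read-out higher numbers stand for higher potency (the scale is a negative logarithm) and lower numbers for lower potency), compound 3 gives 6.41, while compound 2 `COCCC1=C(N2CC2)C(=O)C(C)=C(N2CC2)C1=O` gives 5.57 and compound 1 `CC1=C(N2CC2)C(=O)C(Cc2ccccc2)=C(N2CC2)C1=O` gives 4.85. Compound 4 `CC1=C(N2CC2)C(=O)C(N2CC2)=C(N2CC2)C1=O` differs from compound 3 by a group of 3 heavy atoms (2 carbon, 1 nitrogen; one three-membered non-aromatic ring with 1 hetero atom) in place of a group of 7 heavy atoms (4 carbon, 1 nitrogen, 2 oxygen; no ring), on a double-bonded ring carbon. The measured steps that bear on this position are a number 1.56 log units higher from compound 1 to compound 3 (beyond the scatter) and a number 0.84 log units higher from compound 2 to compound 3 (beyond the scatter); both show the departing group of 7 heavy atoms carrying the higher number, and a number 0.72 log units higher from compound 1 to compound 2 (beyond the scatter) shows that the smaller groups differ among themselves. Nothing measured yet covers aziridin-1-yl entering at this carbon, so the step is expected to be a number 0.81 log units lower from compound 3 to compound 4 (beyond the scatter), downward toward the range of compounds 1 and 2. Compound 4 is estimated at 5.6, within 4.8 to 6.4.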

Compound 4, logarithm of the reciprocal of the active concentration, log(1/C): 6.77
Estimate against measurement, compound 4: 1.17 log units below, outside the stated range (above it).
By their numbers in this assay, from the lowest: compound 1; then compound 2; then compound 3; then compound 4.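

In this assay, aziridin-1-yl on this double-bonded ring carbon gives the highest number of the series: a number 0.36 log units higher from compound 3 to compound 4 (beyond the scatter), a number 1.20 log units higher from compound 2 to compound 4 (beyond the scatter) and a number 1.92 log units higher from compound 1 to compound 4 (beyond the scatter). Heavy-atom count does not order this position, as the group of 3 heavy atoms stands above both groups of 7 heavy atoms and above 2-methoxyethyl. The top number also needs no hydrogen-bond donor in this group, since aziridin-1-yl has 0 hydrogen-bond donors.

Nothing on hand accounts for the rise. Open, on these data alone, is whether the three-membered ring matters or only a nitrogen bound to this carbon, which a dimethylamino group here would test.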